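This account rests on a few compounds, and the source may have more. Where it says the series, first, only, none or still open, it means among the compounds named here.

Three compounds share one core and differ only in the group on a saturated chain carbon bound to an aromatic carbon and a saturated chain carbon. In a physicochemical assay for solubility, in phosphate buffer, measured as kinetic solubility (on this read-out lower numbers stand for lower solubility and higher numbers for higher solubility), compound 1 `CC(C)C(c1ncc[nH]1)c1ccc(-c2ccc3cccc(F)c3c2)[nH]c1=O` gives 20600 nM, compound 2 `CC(C)C(c1ccc(-c2ccc3cccc(F)c3c2)[nH]c1=O)N1CCCCC1=O` gives 23100 nM, and compound 3 `CC(C)C(c1ccc(-c2ccc3cccc(F)c3c2)[nH]c1=O)N1CCN/C1=N\C#N` gives 25200 nM. Compound 2 stands second highest of the three numbers, with compound 3 nearest at a 1.1-fold higher number from compound 2 to compound 3 (0.04 log units; within the scatter) and compound 1 furthest at a 1.1-fold higher number from compound 1 to compound 2 (0.05 log units; within the scatter), and all three values lie within the scatter of one another. Compound 4 `CC(C)C(Cc1nnn[nH]1)c1ccc(-c2ccc3cccc(F)c3c2)[nH]c1=O` has not yet been measured in this assay. It differs from compound 2 as follows: (1H-tetrazol-5-yl)methyl in place of 2-oxopiperidin-1-yl on a saturated chain carbon bound to an aromatic carbon and a saturated chain carbon. The measured steps that bear on this change are a 1.1-fold higher number from compound 1 to compound 2 (0.05 log units; within the scatter), in which a five-membered aromatic ring was exchanged for the 2-oxopiperidin-1-yl, together with a 1.2-fold higher number from compound 1 to compound 3 (0.09 log units; within the scatter) and a 1.1-fold higher number from compound 2 to compound 3 (0.04 log units; within the scatter). Because the steps of a 1.1-fold higher number from compound 1 to compound 2 (0.05 log units; within the scatter), a 1.2-fold higher number from compound 1 to compound 3 (0.09 log units; within the scatter) and a 1.1-fold higher number from compound 2 to compound 3 (0.04 log units; within the scatter) all stay within the scatter, no step beyond the scatter is expected for compound 4 in this assay in either direction. Compound 4 is therefore estimated at 27000 nM, with a range from 13000 nM to 55000 nM, which corresponds to an expected step of a 1.2-fold higher number from compound 2 to compound 4 (0.07 log units; within the scatter).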

Compound 4, solubility: 27300 nM
The estimate for compound 4 lay 1.0-fold (0.00 log units) below the measured number, and the stated range covers the measured number.
By their numbers in this assay, from the lowest: compounds 1, 2, 3 and 4 (each within the scatter of the next).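

In this assay the exchange of 2-oxopiperidin-1-yl for (1H-tetrazol-5-yl)methyl gives a 1.2-fold higher number from compound 2 to compound 4 (0.07 log units; within the scatter) and so extends the flat picture to a group that holds its ring on a methyl link, a five-membered aromatic ring. The comparisons with the other two groups read the same, with a 1.1-fold higher number from compound 3 to compound 4 (0.03 log units; within the scatter) and a 1.3-fold higher number from compound 1 to compound 4 (0.12 log units; within the scatter) so that all four compounds lie within the scatter of one another for this place, a saturated chain carbon bound to an aromatic carbon and a saturated chain carbon. No measurement shown offers a reason for this flat picture.

All four groups contain a ring with nitrogen in it, and the compounds shown leave open whether a group without a ring, such as a carboxylic acid, a primary amine or a longer alkyl chain, would also stay within the scatter of these four. They also leave open whether the same exchanges would read as flat on a core other than the shared core.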